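Lengthening the glycine amide chain on compound 1

The source may hold more compounds than are shown below. What is called first, only, known or untested is meant among the compounds shown, and "the series" means these compounds.

Measured compounds:
compound 1 `Cc1ccc(N2CCN(C(=O)[C@@H]3CN(C4CCOCC4)C[C@H]3c3ccc(Cl)cc3)CC2)c([C@@H](NC(=O)CN)C(C)C)c1` gives 9.1 nM
compound 2 `CC(C)[C@H](NC(=O)CCN(C)C)c1cccc(F)c1N1CCN(C(=O)[C@@H]2CN(C(C)C)C[C@H]2c2ccc(F)c(Cl)c2)CC1` gives 410 nM

In a functional assay on CHO cells for agonist activity at Melanocortin receptor 4 (Homo sapiens), read by cAMP accumulation (on this read-out lower numbers stand for an effect already at smaller amounts and higher numbers for an effect only at larger amounts of compound), compound 1 stands at the lower of the two numbers, and compound 2 is far from it, beyond the usual scatter. Compound 3 `Cc1ccc(N2CCN(C(=O)[C@@H]3CN(C4CCOCC4)C[C@H]3c3ccc(Cl)cc3)CC2)c([C@@H](NC(=O)CCN)C(C)C)c1` differs from compound 1 only by aminomethyl in place of amino on a saturated chain carbon bound to a carbonyl carbon — aminomethyl in place of amino on a saturated chain carbon bound to a carbonyl carbon. For the measured compounds named here, no measured pair shows such a change alone, so only a small step, not beyond the scatter, is expected as a 1.3-fold higher number from compound 1 to compound 3 (0.12 log units; within the scatter). Compound 3 is therefore estimated at 12 nM, within 4 nM to 40 nM.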

Compound 3, half-maximal effective concentration: 6 nM
Estimate against measurement, compound 3: 2.0-fold (0.30 log units) above, and the stated range covers the measured number.
By their numbers in this assay, from the lowest: compounds 3 and 1 (each within the scatter of the next); then compound 2.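

In this assay, putting aminomethyl in place of amino on this saturated chain carbon bound to a carbonyl carbon gives a 1.5-fold lower number from compound 1 to compound 3 (0.18 log units; within the scatter), so the chain can carry this added carbon without a change that can be told from scatter. For the compounds shown here, this is the first reading of a single change here, as compounds 1 and 2 differ in several places. No available measurement offers an explanation for this result. Still open, on these data alone, is whether a longer chain, such as 3-aminopropyl, would also keep the number within the scatter. A carboxylic acid in place of the terminal amine also remains untested among the compounds shown.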